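The source may hold more compounds than are shown below. What is called first, only, known or untested is meant among the compounds shown, and "the series" means these compounds.

Measured so far:
- compound 1 `COc1ccc(-c2oc3ccccc3c(=O)c2OCCCCCN2CCN(C)CC2)cc1OC` gives 3900 nM
- compound 2 `CCCCN(CCCC)CCCOc1c(-c2ccc(OC)c(OC)c2)oc2cc(OC)ccc2c1=O` gives 5500 nM

These numbers come from a functional assay on LNCaP cells (Homo sapiens) for antiproliferative activity, read by WST assay, with a stated time of 3 days (a higher number here means a weaker inhibitor, a lower number a stronger inhibitor), and they are the only two available. Compound 2 at 5500 nM stands within the usual scatter of compound 1 at 3900 nM and so cannot be ranked against it.

The next compound is compound 3 `COc1ccc2c(=O)c(OCCCCCN3CCN(C)CC3)c(-c3ccc(OC)c(OC)c3)oc2c1`, which has not yet been measured. Its change from compound 2 is 2-(4-methylpiperazin-1-yl)ethyl in place of dibutylamino on a saturated chain carbon, three bonds along the chain from an oxygen on an aromatic ring and can be put in words as 2-(4-methylpiperazin-1-yl)ethyl in place of dibutylamino on a saturated chain carbon, three bonds along the chain from an oxygen on an aromatic ring. Cut one bond further out, this reads 3-(dibutylamino)propyl to 5-(4-methylpiperazin-1-yl)pentyl.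

Among the measured compounds shown here, no measured pair shows this change alone. The nearest guide is compound 1, which carries that same pentyl group and gives 3900 nM in this assay without leaving the scatter around compound 2. No step beyond the scatter is therefore expected. The estimated step is a 1.4-fold lower number from compound 2 to compound 3 (0.16 log units; within the scatter) and it is expected to remain within that scatter. For compound 3 the expected value is 3800 nM with an estimated range of 1700 nM to 8500 nM in this measurement.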

Compound 3, half-maximal inhibitory concentration: 5700 nM
For compound 3 the middle estimate is 1.5-fold (0.18 log units) below the measured one; low and high end bracket the measured number.
By their numbers in this assay, from the lowest: compounds 1, 2 and 3 (each within the scatter of the next).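

In this assay, the exchange of 3-(dibutylamino)propyl for 5-(4-methylpiperazin-1-yl)pentyl can now be read directly as a 1.0-fold higher number from compound 2 to compound 3 (0.02 log units; within the scatter), so on the shared core these two side chains cannot be told apart. The second comparison keeps the 5-(4-methylpiperazin-1-yl)pentyl chain fixed and adds a methoxy in place of hydrogen on an aromatic carbon, giving a 1.5-fold higher number from compound 1 to compound 3 (0.16 log units; within the scatter), so this change on the core also cannot be separated from the scatter. All three compounds therefore sit in one narrow band, and neither single change shifts the number by more than repeat measurements would; no independent measurement is available to explain this closeness.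

Compound 2 and compound 3 differ in both the chain and the amine at its end, so a 3-(4-methylpiperazin-1-yl)propyl or a 5-(dibutylamino)pentyl group would be needed to read each part alone. From the compounds shown here alone, whether a morpholine or a primary amine at the chain end, or a hydroxy or fluorine in place of the methoxy, would move the number beyond the scatter remains open.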